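Swapping a Basic Amine Chain for Benzyl on an Orexin Agonist

A few compounds are considered here, and "the series" means these few. Any claim that something is new, unique, unknown or untested is made for them only; others in the source may bear on it.

Measured compounds:
Compound 1, `COc1ccc(CCC(=O)N(C)C)cc1S(=O)(=O)Nc1cccc(NCCNC(=O)c2cccc(C)c2)c1`: > 10000 nM
Compound 2, `COc1ccc(-c2cccc(C(=O)N(C)CCN(C)C)c2)cc1S(=O)(=O)Nc1cccc(NCCNC(=O)c2cccc(C)c2)c1`: 638 nM

Both compounds were tested in a functional assay on CHO-RD-HGA16 cells for agonist activity at Orexin/Hypocretin receptor type 1 (Homo sapiens), read by fluorescence and calcium flux, with a stated time of 30 min; a higher number here means that more compound is needed for the effect, a lower number that less compound is needed. For compound 1 the result is only a limit of the assay, > 10000 nM, so no number is known for it; this is the limit of > 10000 nM in this assay, at which 1 of the 2 values shown sits. Among the compounds with values here, compound 2 gives 638 nM in this assay, and it is the only compound with an actual number. Within the data shown here, the two share the same sulfonamide core, but differ in more than one place, so no single step between measured compounds can be read from them.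

Compound 3, `COc1ccc(-c2cccc(C(=O)N(C)Cc3ccccc3)c2)cc1S(=O)(=O)Nc1cccc(NCCNC(=O)c2cccc(C)c2)c1`, differs from compound 2 in one place: phenyl in place of (dimethylamino)methyl on a saturated chain carbon bound to an amide-type nitrogen. Read one bond further out, the change is 2-(dimethylamino)ethyl to benzyl. Among the measured compounds shown here, no measured step of this kind exists here, so the expectation rests on compound 2 alone. A step of a 1.9-fold higher number from compound 2 to compound 3 (0.27 log units; within the scatter) is expected, most likely a mild weakening that may not clearly exceed the usual scatter. Compound 3 is estimated at 1200 nM, with an expected range from 300 nM to 5000 nM.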

Compound 3, half-maximal effective concentration: > 10000 nM
Compound 3 gave a limit, no number (the forecaster's own chance of this, stated with the estimate: 15%); at least 8.3-fold (0.92 log units) between middle value and limit.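

Within the data shown here, this is the first change that can be read at a single place, and in this assay going from 2-(dimethylamino)ethyl to benzyl on the amide nitrogen gives an at least 15-fold higher number from compound 2 to compound 3 (1.19 log units; beyond the scatter), a large step well beyond the usual scatter. The activity seen in this series therefore depends on what sits at this end of the amide, and the shared core alone does not carry it. For compound 3, the result of > 10000 nM is a limit of the assay and not a number, so the true size of the step stays unknown, and compound 2 remains the only compound here with an actual value: the limit of > 10000 nM in this assay, at which 2 of the 3 values shown sit.

The change removes a chain that holds a nitrogen and brings in an aromatic ring, so this single step cannot tell whether losing the one or gaining the other matters more. A simple 2-aminoethyl group, a longer chain ending in the same dimethylamino group, or a chain ending in a carboxylic acid would be needed to separate these two parts of the change.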